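Adding a Second Chlorine to a Fused Purine-Like Core

A few compounds are considered here, and "the series" means these few. Any claim that something is new, unique, unknown or untested is made for them only; others in the source may bear on it.

Three compounds share a core carrying a chloromethylbenzyl group, and all were tested in a functional assay on HCC 2998 cells (Homo sapiens) for cytotoxicity, read by sulforhodamine B assay, with a stated time of 48 h; on this read-out higher numbers stand for weaker inhibition of growth and lower numbers for stronger inhibition of growth. Compound 1 `ClCc1ccccc1Cn1cnc2ncnc(Cl)c21` gives 2230 nM. Compound 2 `ClCc1cccc(Cn2cnc3nc(Cl)nc(Cl)c32)c1` gives 1900 nM, and compound 3 `Nc1nc(Cl)c2ncn(Cc3cccc(CCl)c3)c2n1` gives 3020 nM. Compound 1 thus sits among three numbers that all lie within the scatter of one another, so no ordering among them can be read.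

Compound 4 `ClCc1ccccc1Cn1cnc2nc(Cl)nc(Cl)c21` differs from compound 1 by a single change, (chloro in place of hydrogen on an aromatic carbon). Among the measured compounds shown here, no measured pair shows this exact step, but compound 2 also carries two chloro groups on its core and gives 1900 nM, close to compound 1. The step of a 1.1-fold lower number from compound 1 to compound 4 (0.05 log units; within the scatter) is expected to be small, in no clear direction, and within the scatter. Compound 4 is therefore estimated at 2000 nM, likely between 900 nM and 4500 nM.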

Compound 4, concentration for 50% growth inhibition: 18600 nM
Estimate against measurement, compound 4: 9.3-fold (0.97 log units) below; the measured number lies above the stated range.
By their numbers in this assay, from the lowest: compounds 2, 1 and 3 (each within the scatter of the next); then compound 4.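

The step at this carbon between two ring nitrogen atoms in this assay is an 8.3-fold higher number from compound 1 to compound 4 (0.92 log units; beyond the scatter) and marks weaker inhibition of growth, so exchanging hydrogen for chloro here is not a neutral change. Compound 2 has the same two chloro groups on the core, with its chloromethyl group placed differently, and gives 1900 nM, so this chloro pair does not bring a high number in every setting. Nothing available explains the loss.

From the compounds shown here alone, it remains open whether a methyl or methoxy group on this carbon would raise the number as well, or whether the step belongs to chloro alone.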